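The compounds below may be only part of what the source reports. "The series", "measured", "known", "first", "only" and "open" are said of these compounds alone.

In a physicochemical assay for solubility, measured as kinetic solubility (on this read-out lower numbers stand for lower solubility and higher numbers for higher solubility), compound 1 `CCC/N=C1\S/C(=C\c2ccc(O)c(C(C)C)c2)C(=O)N1c1ccccc1C` gives 79000 nM and compound 2 `CCC/N=C1\S/C(=C\c2ccc(O)c(C)c2)C(=O)N1c1ccccc1C` gives 78000 nM; the two stand level within the scatter. Compound 3 `CCC/N=C1\S/C(=C\c2ccc(O)c(Cl)c2)C(=O)N1c1ccccc1C` carries one change from compound 2: chloro in place of methyl on an aromatic carbon, ortho to a hydroxy group. Going by the values given here, the one measured step bearing on this is a 1.0-fold lower number from compound 1 to compound 2 (0.01 log units; within the scatter), methyl in place of isopropyl on that same carbon, and it lies within the scatter. No shift beyond the scatter is expected in this assay, and the expected step is a 1.1-fold lower number from compound 2 to compound 3 (0.03 log units; within the scatter). Compound 3 is estimated at 72000 nM, with an expected range from 40000 nM to 110000 nM.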

Compound 3, solubility: 79000 nM
The estimate for compound 3 lay 1.1-fold (0.04 log units) below the measured number; the range from low to high includes it.
By their numbers in this assay, from the lowest: compounds 2, 1 and 3 (each within the scatter of the next).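

In this assay chloro ortho to a hydroxy group stands level with methyl (a 1.0-fold higher number from compound 2 to compound 3 (0.01 log units; within the scatter)) and with isopropyl (no change at the digits printed from compound 1 to compound 3 (within the scatter)). The series at this carbon now spans a halogen as well as two alkyl groups, and all three compounds remain within the scatter of one another. No evidence on the reason for this flat read-out is at hand.

On these data alone, whether an amine or a carboxylic acid on this carbon would stay level remains open. So does the effect of replacing the hydroxy group itself.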